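Swapping a nitrophenyl for a dichlorophenyl on a weak cytotoxic core

The compounds below may be only part of what the source reports. "The series", "measured", "known", "first", "only" and "open" are said of these compounds alone.

Compound 1: `COc1cc(N2C(N)=C(C#N)C(c3ccc([N+](=O)[O-])cc3)C3=C2CC(C)(C)CC3=O)cc(OC)c1OC` — 25000 nM
Compound 2: `COc1ccc(C2C(C#N)=C(N)N(c3cc(OC)c(OC)c(OC)c3)C3=C2C(=O)CC(C)(C)C3)cc1` — "not active" (no number reported)
Compound 3: `COc1cc(N2C(N)=C(C#N)C(c3ccc(OC)c4ccccc34)C3=C2CC(C)(C)CC3=O)cc(OC)c1OC` — "not active" (no number reported)

Compound 1 stands alone with a number in a functional assay on Ehrlich cells (Mus musculus) for cytotoxicity (a higher number here means a weaker inhibitor, a lower number a stronger inhibitor), where compound 1 gives 25000 nM. Compounds 2 and 3 gave no value there at all, only the note that they were inactive. Compound 4, `COc1cc(N2C(N)=C(C#N)C(c3ccc(Cl)cc3Cl)C3=C2CC(C)(C)CC3=O)cc(OC)c1OC`, differs from compound 1 in one place: 2,4-dichlorophenyl in place of 4-nitrophenyl on a saturated ring carbon. Among the compounds with values here, no step between measured compounds exists to lean on, and the two inactive entries tell only that changes at this ring carbon need not improve matters. He expects no step beyond the scatter, with the step from compound 1 to compound 4 estimated at a 1.3-fold higher number from compound 1 to compound 4 (0.11 log units; within the scatter). For compound 4 the estimated value is 32000 nM, ranging from 10000 nM to 100000 nM.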

Compound 4, half-maximal inhibitory concentration: 94700 nM
Compound 4: the middle estimate sits 3.0-fold (0.47 log units) below what was measured; the range from low to high includes it.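

Within the data shown here, with 2,4-dichlorophenyl in place of 4-nitrophenyl on the saturated ring carbon, this assay shows a 3.8-fold higher number from compound 1 to compound 4 (0.58 log units; beyond the scatter), the first readable step at this position. Compound 4 still gives a number, unlike compounds 2 and 3, so a second substituted phenyl here can be placed on the scale, though it is the weaker of the two. Nothing measured here bears on the reason for this step. On these data alone, whether 4-chlorophenyl or 2-chlorophenyl alone would give the same result remains open. So does whether a pyridyl ring or 4-aminophenyl at this carbon would lower the number.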